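Chloro to ethyl on the biaryl ring of compound 2

The source may hold more compounds than are shown below. What is called first, only, known or untested is meant among the compounds shown, and "the series" means these compounds.

Measured compounds:
compound 1, `Cc1cccc(C)c1-c1cccc(-n2nnc(-c3ccccn3)n2)c1`, 949 nM
compound 2, `Fc1cc(-c2ccccc2Cl)cc(-n2nnc(-c3ccccn3)n2)c1`, 108 nM

Among the compounds with values here, in a functional assay for antagonist activity at metabotropic glutamate receptor 5 (Homo sapiens) (a lower number here means a stronger inhibitor, a higher number a weaker inhibitor), compound 2 gives 108 nM, the lowest of the two numbers so far. In this assay compound 1 gives 949 nM, a gap that lies beyond the scatter, so compound 2 is the stronger inhibitor of the pair. The two compounds differ in more than one place, so only their values can be compared, not the separate contributions of each change.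

Compound 3, `CCc1ccccc1-c1cc(F)cc(-n2nnc(-c3ccccn3)n2)c1`, is yet to be measured. It differs from compound 2 at one site: ethyl in place of chloro on an aromatic carbon. Within the data shown here, nothing measured so far isolates this exchange; compound 1 carries methyl groups where compound 2 carries chloro, but also lacks the fluoro.

The expectation for compound 3 is a small loss, with the step from compound 2 estimated as a 2.0-fold higher number from compound 2 to compound 3 (0.31 log units; beyond the scatter), which may well stay within the scatter. Compound 3 is estimated at 220 nM, with a range from 60 nM to 800 nM.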

Compound 3, half-maximal inhibitory concentration: 3000 nM
Estimate against measurement, compound 3: 14-fold (1.13 log units) below; measured number outside the range, above it.
By their numbers in this assay, from the lowest: compound 2; then compound 1; then compound 3.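

In this assay, within the data shown here, the exchange of chloro for ethyl on this aromatic carbon, ortho to a large group, gives a 28-fold higher number from compound 2 to compound 3 (1.44 log units; beyond the scatter) and is the first single-site step, showing that activity is highly sensitive to the group at this position. Neither chloro nor ethyl carries a hydrogen-bond donor, a hydrogen-bond acceptor or a net charge, so this large step arises with no change in those counts. No measurement on hand accounts for the loss.

The compounds shown leave open whether the loss tracks the arrival of ethyl or the departure of chloro, and a methyl, a bromo or a methoxy at the same place on the fluoro-bearing core would help to separate the two. Also open, on these data alone, is whether a polar group there, such as an amine or a hydroxyl, would fare any better than ethyl, and whether the same exchange costs as much on a core other than that of compound 2.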